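A Diethylamino Chain Replaces Hydrogen on the Core

This account rests on a few compounds, and the source may have more. Where it says the series, first, only, none or still open, it means among the compounds named here.

Measured compounds in a functional assay on HL-60 cells (Homo sapiens) for antiproliferative activity, read by MTT assay, with a stated time of 48 h; on this read-out higher numbers stand for weaker inhibition and lower numbers for stronger inhibition:
Compound 1, `Cn1c(N)c(-c2nc3ccccc3[nH]2)c2nc(C#N)c(C#N)nc21`, gives > 50000 nM; this is a limit of the assay, not a number.
Compound 2, `N#Cc1nc2c(-c3nc4ccccc4[nH]3)c(N)n(CCN3CCCC3)c2nc1C#N`, gives 4760 nM.
Compound 3, `N#Cc1nc2c(-c3nc4ccccc4[nH]3)c(N)n(CCO)c2nc1C#N`, gives > 50000 nM; this too is a limit of the assay.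

Compound 1 therefore stands only at a limit, and it shares that place with compound 3, as the limit of > 50000 nM in this assay, at which 2 of the 3 values shown sit, records. Compound 4, `CCN(CC)CCCn1c(N)c(-c2nc3ccccc3[nH]2)c2nc(C#N)c(C#N)nc21`, is not yet measured. It differs from compound 1 as follows: 2-(diethylamino)ethyl in place of hydrogen on a saturated chain carbon bound to an aromatic nitrogen.

The nearest measured step is an at least 10-fold lower number from compound 1 to compound 2 (1.02 log units; beyond the scatter), where a chain carrying a basic nitrogen enters at the same place. The step of an at least 10-fold higher number from compound 2 to compound 3 (1.02 log units; beyond the scatter) shows that swapping that nitrogen for a hydroxy group returns the number to the limit, while a step that the two limits leave unreadable from compound 1 to compound 3 cannot be read. Since compound 4 also carries a nitrogen-bearing chain at this position, a large downward step is expected, and the expected step is an at least 8.3-fold lower number from compound 1 to compound 4 (0.92 log units; beyond the scatter). For compound 4 the expected value in this assay is 6000 nM, within a range from 1500 nM to 30000 nM.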

Compound 4, half-maximal inhibitory concentration: > 730 nM
Compound 4 ended at the assay's limit; the forecaster's own chance of this, stated with the estimate: 20%; the middle value does not contradict the limit.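

In this assay compound 4 gives > 730 nM, which is a limit of the assay and not a number. Among these compounds, no step linking compound 4 to compound 1, compound 2 or compound 3 can therefore be read. The compounds shown leave open how compound 4 truly compares with compound 2.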